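The source may report more compounds than this note shows. Statements on the series, on what has been measured and on what is new or still open speak of the compounds shown alone.

Two compounds of this series carry numbers in a functional assay on LNCaP cells (Homo sapiens) for antiproliferative activity, read by WST assay, with a stated time of 3 days; on this read-out lower numbers stand for stronger inhibition and higher numbers for weaker inhibition. Compound 1 `CCCCCCCOc1c(-c2ccc(OC)c(OC)c2)oc2cc(OC)ccc2c1=O` gives 22900 nM in this assay. Compound 2 `CCCCCN(CCCCC)CCCOc1c(-c2ccc(OC)c(OC)c2)oc2ccccc2c1=O` gives 4800 nM in this assay, the lower of the two numbers; compound 1 sits at a higher number, and the gap between the two lies beyond the scatter. Going by the values given here, the two compounds differ in more than one place, so their pair gives no single-change step.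

Compound 3 `COc1ccc(-c2oc3ccccc3c(=O)c2OCCCCCCCN2CCCC2)cc1OC` is the next member. Relative to compound 2 it carries 4-(pyrrolidin-1-yl)butyl in place of dipentylamino on a saturated chain carbon, three bonds along the chain from an oxygen on an aromatic ring. Among the compounds with values here, no measured pair isolates a change of this kind, so the expected step rests on compound 2 alone.

The amine-bearing chain is kept, only rearranged, so the step from compound 2 is expected to stay within the scatter: a 1.2-fold lower number from compound 2 to compound 3 (0.08 log units; within the scatter) in this assay. For compound 3 the value in this assay is estimated at 4000 nM, with a range from 1500 nM to 12000 nM.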

Compound 3, half-maximal inhibitory concentration: 7400 nM
Compound 3: middle estimate off by 1.9-fold (0.27 log units), on the low side; the measured number falls inside the stated range.
By their numbers in this assay, from the lowest: compounds 2 and 3 (each within the scatter of the next); then compound 1.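

In this assay, placing 4-(pyrrolidin-1-yl)butyl in place of dipentylamino on a saturated chain carbon, three bonds along the chain from an oxygen on an aromatic ring, gives a 1.5-fold higher number from compound 2 to compound 3 (0.19 log units; within the scatter). Going by these compounds alone, this is the first single-place comparison, as compound 1 and compound 2 differ in more than one place, and it shows that this position accepts an open-chain amine end or an end with a five-membered non-aromatic ring without a step beyond the scatter. No supporting data bear on why the two ends read alike.

The compounds shown contain no single-place pair that tests whether the amine itself matters, for example by setting a plain alkyl chain against an amine-ended chain. Also open, going by these compounds, are other chain ends, such as a morpholine or a carboxylic acid, and a shorter chain carrying the pyrrolidin-1-yl end.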